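This account rests on a few compounds, and the source may have more. Where it says the series, first, only, none or still open, it means among the compounds named here.

Measured compounds:
compound 1, `CCSC(=O)C1=C(C)NC(=O)NC1c1ccco1`, 14% in an assay on membranes from HeLa cells for displacement of a labelled ligand from adenosine receptor A3 (Homo sapiens), read by scintillation counting, with a stated time of 180 min, tested at 1 uM; on this read-out lower numbers stand for less inhibition and higher numbers for more inhibition at the one concentration tested (going by the name of the read-out)
compound 2, `CCSC(=O)C1=C(C)NC(=O)NC1c1ccsc1`, 2% in the same assay

Both measured compounds share one core and differ only in the aromatic group attached to a saturated ring carbon. Replacing furan-2-yl with thiophen-3-yl gave a number 12 percentage points lower from compound 1 to compound 2 (beyond the scatter), so compound 2 stands lowest of the two numbers, with compound 1 the nearest number above it.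

Compound 3, `CC1=C(C(=O)OCC2CC2)C(c2ccsc2)NC(=O)N1`, has not yet been measured. It keeps the thiophen-3-yl group of compound 2 and changes the other side of the molecule: cyclopropylmethoxy in place of ethylsulfanyl on a carbonyl carbon. Going by the values given here, no measured step touches this carbonyl carbon, so nothing in the two numbers so far shows how such a change moves the read-out; the only step known concerns the aromatic group, not this position. Compound 2 shows a very low number, and with no evidence pointing either way the expectation for compound 3 is a value close to that, a step of a number 6 percentage points higher from compound 2 to compound 3 (within the scatter) that is expected to stay within the scatter. Compound 3 is therefore estimated at 8%, with an expected range from 0% to 30%.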

Compound 3, a percentage reported as inhibition, at one concentration (the size of the read-out at that concentration, not a potency): 3%
For compound 3 the middle estimate is 5 percentage points above the measured one; the range from low to high includes it.
By their numbers in this assay, from the lowest: compounds 2 and 3 (each within the scatter of the next); then compound 1.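

In this assay, going by these compounds alone, putting cyclopropylmethoxy in place of ethylsulfanyl on the carbonyl carbon gave a number 1 percentage points higher from compound 2 to compound 3 (within the scatter), the first reading of any change at this position. With the thiophen-3-yl group held constant, this exchange of a sulfur-linked open chain for an oxygen-linked group carrying a three-membered ring therefore gives two compounds that this read-out cannot tell apart, although both numbers are so small that they say little about how this position would behave in a compound showing clear inhibition. Nothing available gives a reason for this result.

It remains open whether the same exchange would read the same way with furan-2-yl on the saturated ring carbon, where the measured number is higher, since that pairing is not among the compounds shown. Also unknown is how quite different groups on the carbonyl carbon would read, such as an amine, which would turn the ester into an amide, or a longer carbon chain on the oxygen.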